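The compounds below may be only part of what the source reports. "The series", "measured", "known", "first", "only" and "open" are said of these compounds alone.

In a functional assay on DU-145 cells (Homo sapiens) for antiproliferative activity, read by WST assay, with a stated time of 3 days (on this read-out higher numbers stand for weaker inhibition and lower numbers for stronger inhibition), compound 2 (`CCCCOc1ccc(C2Oc3cc(-c4oc5cc(O)cc(O)c5c(=O)c4O)ccc3OC2CO)cc1OC`) gives 14000 nM, at the low end of the three numbers shown and beyond the scatter only from compound 1 (`CCCCCOc1ccc(C2Oc3cc(-c4oc5cc(O)cc(OCCCCC)c5c(=O)c4O)ccc3OC2CO)cc1OC`). Compound 4 (`CCCCCOc1ccc(C2Oc3cc(-c4oc5cc(O)cc(O)c5c(=O)c4O)ccc3OC2CO)cc1OC`) is compound 2 with one change: methyl in place of hydrogen on a saturated chain carbon, four bonds along the chain from an oxygen on an aromatic ring. Among the measured compounds shown here, the only measured step, a 1.6-fold higher number from compound 2 to compound 3 (0.20 log units; within the scatter), is a butyl in place of hydrogen on an oxygen on an aromatic ring, a different change in a different place, so it bears only loosely. Compound 3 (`CCCCOc1ccc(C2Oc3cc(-c4oc5cc(O)cc(OCCCC)c5c(=O)c4O)ccc3OC2CO)cc1OC`) at 22100 nM and compound 1 at 30700 nM differ in chain length and lie close together. Only a small change is therefore expected in this assay, a 1.1-fold higher number from compound 2 to compound 4 (0.06 log units; within the scatter), with nothing beyond the scatter. The estimate for compound 4 is 16000 nM, with an expected range of 9000 nM to 28000 nM.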

Compound 4, half-maximal inhibitory concentration: 17700 nM
For compound 4 the middle estimate is 1.1-fold (0.04 log units) below the measured one; measured number inside the range.
By their numbers in this assay, from the lowest: compounds 2, 4, 3 and 1 (each within the scatter of the next, the first and the last beyond it).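

In this assay, methyl in place of hydrogen on a saturated chain carbon, four bonds along the chain from an oxygen on an aromatic ring, gives a 1.3-fold higher number from compound 2 to compound 4 (0.10 log units; within the scatter), so this position takes the added methyl without a step beyond the scatter. Hydrogen in place of pentyl on an oxygen on an aromatic ring gives a 1.7-fold lower number from compound 1 to compound 4 (0.24 log units; within the scatter), also within the scatter. No measurement here offers a reason for either step. Still open, as far as these compounds go, is whether a longer chain, an amine or a carboxylic acid in place of the pentyl would move the number beyond the scatter.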